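Triazolyl for Ethyl on a Shared Piperidine Amide Core

The source may hold more compounds than are shown below. What is called first, only, known or untested is meant among the compounds shown, and "the series" means these compounds.

Measured so far:
Compound 1, `CCc1cccc(NC(=O)C2CCCN(C(=O)c3cc(C(F)(F)F)cc(C(F)(F)F)c3)C2)c1`: 0%
Compound 2, `N#Cc1cccc(C(=O)N2CCCC(C(=O)Nc3ccc(Cl)cc3)C2)c1`: 0%

In an ADME assay on PC-3 cells (Homo sapiens) for cytotoxicity, read by WST assay, tested at 100 uM (a higher number here means more inhibition at the concentration tested (going by the name of the read-out), a lower number less inhibition), compound 1 gives 0%, and compound 2 gives 0%, so compound 1 stands level with compound 2 at the digits shown, within the scatter. Compound 3, `Cn1cnnc1-c1cccc(NC(=O)C2CCCN(C(=O)c3cc(C(F)(F)F)cc(C(F)(F)F)c3)C2)c1`, is not yet measured. It differs from compound 1 in one place: 4-methyl-4H-1,2,4-triazol-3-yl in place of ethyl on an aromatic carbon. Within the data shown here, no step between measured compounds is available to calibrate this change. Compound 3 is expected to show no step beyond the scatter, a number 2 percentage points higher from compound 1 to compound 3 (within the scatter), because compound 1 sits at 0%. The estimate for compound 3 is 2%, ranging from -8% to 15%.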

Compound 3, a percentage reported as inhibition, at one concentration (the size of the read-out at that concentration, not a potency): 0%
Beside the measured number, compound 3's estimate is 2 percentage points above it, within the range that was stated.
By their numbers in this assay, from the lowest: compounds 1, 2 and 3 (each within the scatter of the next).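

In this assay, among these compounds, 4-methyl-4H-1,2,4-triazol-3-yl in place of ethyl on the aromatic carbon gives no change at the digits printed from compound 1 to compound 3 (within the scatter), the first step that can be read at this position. The position therefore accepts a five-membered aromatic ring with 3 hetero atoms in place of a two-carbon group, without any step beyond the scatter on the shared core. The compounds shown leave open whether an amine or a carboxylic acid on this same carbon would give any inhibition in this assay. Nothing available explains the absence of a step here.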